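Compound 2 to compound 3: a limit-bound pair

The source may hold more compounds than are shown below. What is called first, only, known or untested is meant among the compounds shown, and "the series" means these compounds.

Compound 1 `Fc1ccc2nc(-c3ccccc3)nc(Nc3ccccc3)c2c1` opens the series. In a functional assay on MDA-MB-231 cells (Homo sapiens) for cytotoxicity, read by MTT assay, with a stated time of 48 h (on this read-out lower numbers stand for stronger inhibition and higher numbers for weaker inhibition), compound 1 reaches only a limit of the assay, > 50000 nM. Compound 2 `Fc1cccc(-c2nc(Nc3ccccc3F)c3cc(F)ccc3n2)c1` follows. In this assay compound 2 likewise returns only a limit, > 50000 nM. Both values rest at the limit of > 50000 nM in this assay, at which 2 of the 2 values shown sit, so compound 2 stands nowhere above that floor. Compound 3 `Fc1cccc(-c2nc(Nc3cccc(Br)c3)c3cc(F)ccc3n2)c1` carries 3-bromophenyl in place of 2-fluorophenyl on a nitrogen on an aromatic ring. Among the measured compounds shown here, no measured pair shows what such a change does here. The step expected is a number no higher from compound 2 to compound 3 (the limit leaves the size open), none beyond the scatter. Compound 3 is therefore expected at 50000 nM, within 20000 nM to 120000 nM, most likely again as a limit.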

Compound 3, half-maximal inhibitory concentration: > 50000 nM
Compound 3 was reported as a limit; the forecaster's own chance of this, stated with the estimate: 75%; the middle value lies on the limit itself.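

Compound 2 and compound 3 both sit at a limit, so no step between them can be read in this assay: the limit of > 50000 nM in this assay, at which 3 of the 3 values shown sit.

The compounds shown leave open which change on the shared core, if any, gives a readable value.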